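The compounds below may be only part of what the source reports. "The series", "measured", "known", "first", "only" and "open" are said of these compounds alone.

Measured compounds:
- Compound 1, `Cn1c(=O)c2c(nc(SCCc3ccc(Br)cc3)n2C)n(C)c1=O`: 108000 nM
- Compound 2, `Cn1c(=O)c2c(nc([S+]([O-])CCc3ccc(Cl)cc3)n2C)n(C)c1=O`: 203000 nM

Of the compounds shown here, two have been tested in an assay on microsomes for inhibition of Amine oxidase [flavin-containing] A (Homo sapiens), read by fluorescence and spectrophotometry, with a stated time of 20 min; on this read-out lower numbers stand for stronger inhibition and higher numbers for weaker inhibition. Compound 1, `Cn1c(=O)c2c(nc(SCCc3ccc(Br)cc3)n2C)n(C)c1=O`, gives 108000 nM in this assay. Compound 2, `Cn1c(=O)c2c(nc([S+]([O-])CCc3ccc(Cl)cc3)n2C)n(C)c1=O`, gives 203000 nM in this assay. Compound 2 holds the higher of the two numbers, but the gap to compound 1 lies within the usual scatter of repeated measurements, so the two compounds cannot be told apart on these data. Both numbers are very high, meaning that neither compound inhibits the enzyme to any strong degree.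

The next compound, compound 3, `Cn1c(=O)c2c(nc([S+]([O-])Cc3ccccc3)n2C)n(C)c1=O`, has not yet been measured in this assay. It differs from compound 2 in one place: phenyl in place of 4-chlorobenzyl on a saturated chain carbon bound to a sulfur. Among the measured compounds shown here, no step between measured compounds covers this kind of change, so the direction cannot be read from a prior example. Because compound 2 already sits at 203000 nM in this assay, little room remains for a large rise, and a fall would need to be large to be noticed. The expected step of a 1.5-fold higher number from compound 2 to compound 3 (0.17 log units; within the scatter) is therefore small, toward a somewhat higher number, and may well stay within the scatter. Compound 3 is expected to give about 300000 nM in this assay, with a plausible range from 100000 nM to 1000000 nM.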

Compound 3, half-maximal inhibitory concentration: 250000 nM
The estimate for compound 3 lay 1.2-fold (0.08 log units) above the measured number; measured number inside the range.
By their numbers in this assay, from the lowest: compounds 1, 2 and 3 (each within the scatter of the next, the first and the last beyond it).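

In this assay, putting phenyl in place of 4-chlorobenzyl on a saturated chain carbon bound to a sulfur gives a 1.2-fold higher number from compound 2 to compound 3 (0.09 log units; within the scatter), so this change cannot be told apart from no change at all. The swap removes the chlorine and takes the group from 8 heavy atoms to 6, while one six-membered aromatic ring of carbon only stays in place, and at this very weak level of inhibition the read-out does not register that difference. No evidence is available that would explain this result.

On these data alone, the two groups compared here both carry that same kind of aromatic ring, so it remains open whether something of a different kind at this place, such as an amine, a carboxylic acid or a longer chain, would give a number beyond the scatter. Compound 1 and compound 2 differ in two places, so the oxygen on the sulfur cannot be judged on its own, and neither can the swap of bromine for chlorine.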